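The compounds below may be only part of what the source reports. "The series", "measured", "known", "first", "only" and "open" are said of these compounds alone.

In a functional assay on SNU-423 cells (Homo sapiens) for inhibition, read by MTT assay, with a stated time of 72 h (on this read-out lower numbers stand for stronger inhibition and higher numbers for weaker inhibition), compound 1 `Nc1nc2cc(-c3nn(CCCCC(=O)NO)c4ncnc(N)c34)ccc2o1` gives 3030 nM and compound 2 `Nc1nc2cc(-c3nn(CCCCCCCCC(=O)NO)c4ncnc(N)c34)ccc2o1` gives 4940 nM, so compound 2 stands within the scatter of compound 1. Compound 3 `CNC(=O)CCCCCCCn1nc(-c2ccc3oc(N)nc3c2)c2c(N)ncnc21` has methylcarbamoyl in place of the (hydroxycarbamoyl)methyl of compound 2: methylcarbamoyl in place of (hydroxycarbamoyl)methyl on a saturated chain carbon, seven bonds along the chain from an aromatic nitrogen. Going by the values given here, the only measured step, a 1.6-fold higher number from compound 1 to compound 2 (0.21 log units; within the scatter), changes the chain but keeps the hydroxycarbamoyl group, so no measured step tests this exchange and the expectation is loose. A step of a 3.0-fold higher number from compound 2 to compound 3 (0.48 log units; beyond the scatter) is expected, towards a higher number. The estimated value for compound 3 is 15000 nM, within an expected range from 5000 nM to 50000 nM.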

Compound 3, half-maximal inhibitory concentration: 280 nM
Estimate against measurement, compound 3: 54-fold (1.73 log units) above; the whole stated range lies above it.
By their numbers in this assay, from the lowest: compound 3; then compounds 1 and 2 (each within the scatter of the next).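

With methylcarbamoyl at the chain end, this assay shows an 18-fold lower number from compound 2 to compound 3 (1.25 log units; beyond the scatter), and the comparison with the shorter hydroxycarbamoyl compound shows an 11-fold lower number from compound 1 to compound 3 (1.03 log units; beyond the scatter), so a hydroxycarbamoyl end is not required for activity here. Among these compounds, the change of end group moves the number beyond the scatter, whereas the chain change between compound 1 and compound 2 stays within it. Nothing available explains this gain. Open, as far as these compounds go, is how a carboxylic acid or a primary amide would compare at this chain end, and whether methylcarbamoyl keeps this value on a shorter chain.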